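The source may report more compounds than this note shows. Statements on the series, on what has been measured and on what is new or still open speak of the compounds shown alone.

Measured compounds:

Compound 1 `Cc1cc(-c2ccccc2)ccc1C(=O)N[C@@H](CCCN=C(N)N)B1O[C@@H]2CC3CC(C3(C)C)[C@]2(C)O1`: 4.2 nM
Compound 2 `COC(=O)NS(=O)(=O)c1ccccc1-c1ccc(C(=O)N[C@@H](CCCN=C(N)N)B2O[C@@H]3CC4CC(C4(C)C)[C@]3(C)O2)c(C)c1`: 0.64 nM

These two compounds were tested in an assay on isolated protein for inhibition of serine protease 1 (Homo sapiens); on this read-out lower numbers stand for stronger inhibition and higher numbers for weaker inhibition. Compound 1 gives 4.2 nM in this assay, and compound 2 gives 0.64 nM. Compound 2 therefore stands at the lower of the two numbers, and the gap between them, a 6.6-fold lower number from compound 1 to compound 2 (0.82 log units; beyond the scatter), is beyond the usual scatter. Going by the values given here, that single step, (methoxycarbonyl)sulfamoyl in place of hydrogen on an aromatic carbon, is the only measured comparison available.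

Compound 3 `Cc1cc(-c2ccccc2S(=O)(=O)NC(C)(C)C)ccc1C(=O)N[C@@H](CCCN=C(N)N)B1O[C@@H]2CC3CC(C3(C)C)[C@]2(C)O1` differs from compound 2 in one place: tert-butyl in place of methoxycarbonyl on a sulfonamide nitrogen. Among the compounds with values here, no measured step touches the group on this sulfonamide nitrogen itself; the step from compound 1 to compound 2 shows only that adding the whole sulfamoyl group lowered the number, not what its nitrogen substituent contributes. With the sulfamoyl group kept in compound 3, a small shift in either direction seems the most likely outcome, and the expected step of a 1.9-fold higher number from compound 2 to compound 3 (0.27 log units; within the scatter) stays close to the scatter. Compound 3 is thus estimated at 1.2 nM in this assay, with a range from 0.3 nM to 5 nM.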

Compound 3, inhibition constant: 0.7 nM
Compound 3: middle estimate off by 1.7-fold (0.23 log units), on the high side, within the range that was stated.
By their numbers in this assay, from the lowest: compounds 2 and 3 (each within the scatter of the next); then compound 1.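

In this assay, tert-butyl in place of methoxycarbonyl on the sulfonamide nitrogen gives a 1.1-fold higher number from compound 2 to compound 3 (0.04 log units; within the scatter), so these two groups cannot be told apart here, although tert-butyl has only carbon as its heavy atoms and no hydrogen-bond acceptors. Against the compound without any sulfamoyl group, (tert-butyl)sulfamoyl in place of hydrogen on an aromatic carbon gives a 6.0-fold lower number from compound 1 to compound 3 (0.78 log units; beyond the scatter), which shows that the lower number does not depend on the methoxycarbonyl group or its two hydrogen-bond acceptors. Nothing available explains why the two groups read alike.

As far as these compounds go, it remains open whether a plain hydrogen, an amine-bearing chain or a carboxylic acid-bearing chain on the sulfonamide nitrogen would also keep the number in this assay at this level. From the compounds shown here alone, it is also open whether the sulfamoyl group itself is needed, or whether a simpler group on that aromatic carbon, such as a carboxylic acid or a methylsulfonyl group, would lower the number as much.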